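The source may report more compounds than this note shows. Statements on the series, on what has been measured and on what is new or still open speak of the compounds shown alone.

For the measured compounds named here, compound 1 `O=C(CCCCCn1cc(Nc2ncc(Cl)c(Nc3cccc(Cl)c3)n2)cn1)NO` is one of two compounds measured in a functional assay on Jurkat cells (Homo sapiens) for antiproliferative activity, read by MTT assay, with a stated time of 48 h; on this read-out lower numbers stand for stronger inhibition and higher numbers for weaker inhibition. In this assay compound 1 gives 50 nM, the lower of the two numbers recorded. Compound 2 `CNc1nc(Nc2cnn(CCCCCCC(=O)NO)c2)ncc1Cl` gives 70 nM in this assay, a value that sits within the usual scatter of the number for compound 1, so the two cannot be ranked against each other on these data alone.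

Compound 3 `O=C(CCCCCn1cc(Nc2ncc(Cl)c(Nc3ccccc3Cl)n2)cn1)NO` has not yet been measured in this assay. It differs from compound 1 in one place: 2-chlorophenyl in place of 3-chlorophenyl on a nitrogen on an aromatic ring. Going by the values given here, no pair of measured compounds shows this kind of rearrangement, so there is no measured step to lean on; the two values known share the same aryl group and say nothing about it.

The step from compound 1 to compound 3 in this assay is expected to be a modest weakening, a 2.4-fold higher number from compound 1 to compound 3 (0.38 log units; beyond the scatter), of a size that may only just exceed the scatter. Compound 3 is therefore estimated at 120 nM in this assay, with a range from 40 nM to 400 nM.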

Compound 3, half-maximal inhibitory concentration: 310 nM
Compound 3: the middle estimate sits 2.6-fold (0.41 log units) below what was measured, within the range that was stated.
By their numbers in this assay, from the lowest: compounds 1 and 2 (each within the scatter of the next); then compound 3.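

In this assay, the change from 3-chlorophenyl to 2-chlorophenyl on the nitrogen gives a 6.2-fold higher number from compound 1 to compound 3 (0.79 log units; beyond the scatter). The earlier compounds shown here offered no comparison at this place, and this pair shows that the same atoms, joined differently, can be told apart beyond the scatter, so the place of the chlorine on this aryl group matters in this read-out. No measured evidence bears on why the two compounds differ.

A plain phenyl or a 4-chlorophenyl group on the same nitrogen is not among the compounds shown, so it remains open how either would compare with the 3-chlorophenyl and 2-chlorophenyl groups. For the compounds shown here, also open is whether the same step would appear with a longer chain in place of the one shared by compound 1 and compound 3.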